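The source may report more compounds than this note shows. Statements on the series, on what has been measured and on what is new or still open speak of the compounds shown alone.

Compound 1 `O=C(COc1cccc2ccccc12)N/N=C/c1ccc(Cl)cc1` gives, in an ADME assay on MT4 cells (Homo sapiens) for cytotoxicity, read by MTT assay, with a stated time of 4 days (a lower number here means that less compound is tolerated, a higher number that more compound is tolerated), a value of 87.6 ug/mL, the highest of the three numbers available. Compound 2 `COc1cc(/C=N/NC(=O)COc2cccc3ccccc23)cc(OC)c1OC` gives 13.4 ug/mL, and compound 3 `C/C(=N\NC(=O)COc1cccc2ccccc12)c1ccccc1O` gives 11.3 ug/mL, both lying beyond the scatter below compound 1. Within the data shown here, no pair of measured compounds differs in a single place, so no measured step guides the change to compound 4 `O=C(COc1cccc2ccccc12)N/N=C/c1cccc(Br)c1`, which differs from compound 1 as follows: 3-bromophenyl in place of 4-chlorophenyl on a carbon with a double bond to nitrogen. With the shared core untouched, a small step is expected, either none beyond the scatter or a modestly lower number; the expected step is a 1.5-fold lower number from compound 1 to compound 4 (0.16 log units; within the scatter). Compound 4 is therefore estimated at 60 ug/mL, within a range from 30 ug/mL to 120 ug/mL.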

Compound 4, half-maximal cytotoxic concentration: 87.4 ug/mL
Estimate against measurement, compound 4: 1.5-fold (0.16 log units) below; low and high end bracket the measured number.
By their numbers in this assay, from the lowest: compounds 3 and 2 (each within the scatter of the next); then compounds 4 and 1 (each within the scatter of the next).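

In this assay, among these compounds, replacing 4-chlorophenyl with 3-bromophenyl on a carbon with a double bond to nitrogen gives a 1.0-fold lower number from compound 1 to compound 4 (0.00 log units; within the scatter), the first single-place comparison in this set. Both the halogen and its ring position change in this step, so it shows that this combined change leaves the number within the scatter, but it does not separate the two changes. Nothing available explains the result. The compounds shown leave open how 3-chlorophenyl or 4-bromophenyl would compare. They also leave open whether a phenyl ring bearing an amine or a carboxylic acid would give a similar number.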